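Replacing an Amide with a Carbamate on a Shared Core

This account rests on a few compounds, and the source may have more. Where it says the series, first, only, none or still open, it means among the compounds named here.

Three compounds were measured in an ADME assay on TZM cells (Homo sapiens) for cytotoxicity, with a stated time of 1 days; on this read-out higher numbers stand for lower toxicity in this test and lower numbers for higher toxicity in this test. Compound 1 `Cc1cc(CCC#N)cc(C)c1Oc1cc(Nc2ccc(C#N)cc2)c(N)cc1C(=O)N(C)C` gives 38200 nM, compound 2 `CCNC(=O)c1cc(N)c(Nc2ccc(C#N)cc2)cc1Oc1c(C)cc(CCC#N)cc1C` gives 105000 nM, and compound 3 `Cc1cc(CCC#N)cc(C)c1Oc1cc(Nc2ccc(C#N)cc2)c(N)cc1C(=O)NC(C)C` gives 184000 nM, the highest of the three numbers. The step of a 4.8-fold higher number from compound 1 to compound 3 (0.68 log units; beyond the scatter) lies beyond the scatter, as does a 2.7-fold higher number from compound 1 to compound 2 (0.44 log units; beyond the scatter), whereas a 1.8-fold higher number from compound 2 to compound 3 (0.24 log units; within the scatter) stays within it.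

Compound 4 `CNC(=O)OCc1cc(N)c(Nc2ccc(C#N)cc2)cc1Oc1c(C)cc(CCC#N)cc1C` differs from compound 3 in one place: ((methylcarbamoyl)oxy)methyl in place of isopropylcarbamoyl on an aromatic carbon. The measured steps all concern the substituent on the amide nitrogen and span a modest range; none of them replaces the isopropylcarbamoyl group itself with a group of a different kind, so they bear only loosely on this change. One therefore expects no step beyond the usual variation in this assay, and the direction cannot be called from these data. For compound 4 the estimate is 90000 nM, within a range from 30000 nM to 300000 nM. The expected step of a 2.0-fold lower number from compound 3 to compound 4 (0.31 log units; beyond the scatter) is accordingly small and uncertain in sign.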

Compound 4, half-maximal cytotoxic concentration: 46800 nM
The estimate for compound 4 lay 1.9-fold (0.28 log units) above the measured number; the range from low to high includes it.
By their numbers in this assay, from the lowest: compounds 1 and 4 (each within the scatter of the next); then compounds 2 and 3 (each within the scatter of the next).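

In this assay the group on this aromatic carbon can itself be exchanged with a measurable result: ((methylcarbamoyl)oxy)methyl gives a 3.9-fold lower number from compound 3 to compound 4 (0.59 log units; beyond the scatter) against isopropylcarbamoyl and a 2.2-fold lower number from compound 2 to compound 4 (0.35 log units; beyond the scatter) against ethylcarbamoyl. Against dimethylcarbamoyl the same group gives a 1.2-fold higher number from compound 1 to compound 4 (0.09 log units; within the scatter) and so stays within the scatter, which means the outcome of the exchange depends on which amide it replaces. Nothing in the data on hand explains these steps.

Whether the picture would hold with an ethyl or isopropyl group on the carbamate nitrogen stays open, as the compounds shown carry only methyl there. Also open, on these data alone, is how a hydroxymethyl group or a carboxylic acid on this aromatic carbon would compare with the amides and the carbamate.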